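This account rests on a few compounds, and the source may have more. Where it says the series, first, only, none or still open, it means among the compounds named here.

Measured compounds in a functional assay on CHO cells for inhibition of transient receptor potential cation channel subfamily V member 1 (Homo sapiens); a lower number here means a stronger inhibitor, a higher number a weaker inhibitor: compound 1 `C/C(=C\c1ccc(C(C)(C)C)cc1)C(=O)Nc1ccc2c(c1)OCCO2` gives 600 nM. Compound 2 `O=C(/C=C/c1ccccc1)Nc1ccc2c(c1)OCCO2` gives > 4000 nM, a limit of the assay. Compound 3 `Cc1ccc(/C=C/C(=O)Nc2ccc3c(c2)OCCO3)cc1` gives 1100 nM.

Compound 3 and compound 1 lie within the scatter of each other, so no order between them is read. Within the data shown here, the one single-place step available, an at least 3.6-fold lower number from compound 2 to compound 3 (0.56 log units; beyond the scatter), shows that a methyl on the aromatic carbon lowers the number; its size is bounded only because of the limit of > 4000 nM in this assay, at which 1 of the 3 values shown sits.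

Compound 4 `CC(C)c1ccc(/C=C/C(=O)Nc2ccc3c(c2)OCCO3)cc1` takes the step (isopropyl in place of methyl on an aromatic carbon), para to a large group. Among the measured compounds shown here, the methyl step gives the only direct guide; the larger group of compound 1 with 600 nM suggests bulk at this position is tolerated. A modest further lowering is expected, a 2.2-fold lower number from compound 3 to compound 4 (0.34 log units; beyond the scatter). Compound 4 is estimated at 500 nM, range 200 nM to 1400 nM.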

Compound 4, half-maximal inhibitory concentration: 82 nM
The estimate for compound 4 lay 6.1-fold (0.79 log units) above the measured number; the whole stated range lies above it.
By their numbers in this assay, from the lowest: compound 4; then compounds 1 and 3 (each within the scatter of the next). At a limit, above all of these: compound 2.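

Isopropyl in place of methyl gives a 13-fold lower number from compound 3 to compound 4 (1.13 log units; beyond the scatter), so this position, on an aromatic carbon para to a large group, still responds beyond methyl, which the single earlier step could not show. Isopropyl in place of hydrogen gives an at least 48-fold lower number from compound 2 to compound 4 (1.68 log units; beyond the scatter), and the size of that step is bounded only by a limit on compound 2: the limit of > 4000 nM in this assay, at which 1 of the 4 values shown sits.

Open, as far as these compounds go, is whether the number keeps falling with a longer chain such as butyl, or how a cyclopropyl or methoxy group fares at this position. From the compounds shown here alone, compound 1 differs from compound 4 in more than one place, so the effect of tert-butyl alone on the core of compound 4 also stays open.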